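Triazole Substituent Change in a Furanone Series

The source may hold more compounds than are shown below. What is called first, only, known or untested is meant among the compounds shown, and "the series" means these compounds.

compound 1 `O=C1O[C@H]([C@@H](O)Cn2cc(-c3cc(C(F)(F)F)cc(C(F)(F)F)c3)nn2)C(OCc2ccccc2)=C1OCc1ccccc1` — 33800 nM
compound 2 `COc1ccccc1-c1cn(C[C@H](O)[C@H]2OC(=O)C(OCc3ccccc3)=C2OCc2ccccc2)nn1` — > 100000 nM

In a functional assay on HepG2 cells (Homo sapiens) for antiproliferative activity, read by MTT assay, with a stated time of 72 h (a higher number here means a weaker inhibitor, a lower number a stronger inhibitor), compound 1 gives 33800 nM. For compound 2 this assay reports no number but only a limit, > 100000 nM. Compound 2 therefore sits at the limit of > 100000 nM in this assay, at which 1 of the 2 values shown sits. Compound 3 `O=C1O[C@H]([C@@H](O)Cn2cc(CCO)nn2)C(OCc2ccccc2)=C1OCc1ccccc1` differs from compound 2 by 2-hydroxyethyl in place of 2-methoxyphenyl on an aromatic carbon. Among the compounds with values here, no measured pair in this set mirrors that change, so no direction can be read from the data. The author expects the step from compound 2 to compound 3 in this assay to be a number no higher from compound 2 to compound 3 (the limit leaves the size open), within the scatter. Compound 3 is estimated at 100000 nM, from 30000 nM to 300000 nM, and may again come back only as a limit.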

Compound 3, half-maximal inhibitory concentration: 68100 nM
Estimate against measurement, compound 3: 1.5-fold (0.17 log units) above; low and high end bracket the measured number.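

In this assay, placing 2-hydroxyethyl in place of 2-methoxyphenyl on this aromatic carbon gives an at least 1.4-fold lower number from compound 2 to compound 3 (0.16 log units; that floor lies within the scatter). Compound 3 thus shows that this position can carry a chain with no ring and still return a measured number. The true size of the step stays unknown because compound 2 has only a limit as its value: the limit of > 100000 nM in this assay, at which 1 of the 3 values shown sits.

The compounds shown leave open whether the hydroxyl end of the chain matters, since no plain ethyl group stands beside it. They also leave open how an amine, a carboxylic acid or a longer chain would read here.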